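Dichlorophenyl Swap Across Two Related Cores

A few compounds are considered here, and "the series" means these few. Any claim that something is new, unique, unknown or untested is made for them only; others in the source may bear on it.

Compound 3 `O=C(/C=C/c1ccccc1)Nc1cc2c(Nc3cc(Cl)cc(Cl)c3)ncnc2s1` gives 5800 nM in a functional assay on MCF7 cells (Homo sapiens) for antiproliferative activity, read by MTT assay, with a stated time of 48 h; on this read-out lower numbers stand for stronger inhibition and higher numbers for weaker inhibition. Compound 1 `O=C(/C=C/c1ccccc1)Nc1cc2c(Nc3ccc(Cl)c(Cl)c3)ncnc2s1` differs by 3,4-dichlorophenyl in place of 3,5-dichlorophenyl on a nitrogen on an aromatic ring and in this assay compound 1 gives 15300 nM, so that a 2.6-fold higher number from compound 3 to compound 1 (0.42 log units; beyond the scatter). Compound 2 `O=C(/C=C/c1ccccc1)Nc1cc2ncnc(Nc3cc(Cl)cc(Cl)c3)c2s1` carries the same groups on a different core; the difference between the two cores is not broken down here. In this assay compound 2 reaches only > 100000 nM, which is a limit of the assay and not a number, (the limit of > 100000 nM in this assay, at which 1 of the 3 values shown sits). Compound 4 `O=C(/C=C/c1ccccc1)Nc1cc2ncnc(Nc3ccc(Cl)c(Cl)c3)c2s1` is compound 2 with 3,4-dichlorophenyl in place of 3,5-dichlorophenyl on a nitrogen on an aromatic ring, the same kind of change as from compound 3 to compound 1. Because that earlier step a 2.6-fold higher number from compound 3 to compound 1 (0.42 log units; beyond the scatter) ran toward weaker inhibition, compound 4 is expected to remain without measurable activity, with an estimated 150000 nM in this assay. This corresponds to an expected step that the limit leaves unreadable from compound 2 to compound 4. For compound 4 the expected range runs from 70000 nM to 400000 nM.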

Compound 4, half-maximal inhibitory concentration: > 100000 nM
Compound 4: no number, only a limit; the forecaster's own chance of this, stated with the estimate: 80%; the middle value lies beyond the limit too.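

In this assay, for the compounds shown here, compound 2 and compound 4 each give only a limit of the assay and not a number, and no step between them can be read. On these data alone, whether 3,4-dichlorophenyl in place of 3,5-dichlorophenyl changes anything on the core of compound 2, as it does on the core of compound 3, stays open.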